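This account rests on a few compounds, and the source may have more. Where it says the series, first, only, none or still open, it means among the compounds named here.

Compound 1 `COc1cc2nc(N3CCCN(C(=O)N4CCOCC4)CC3)cc(N)c2c(-c2ccccc2)c1OC` was measured in an in vitro ADME assay on microsomes from liver (Canis lupus familiaris) for metabolic stability, tested at 1 uM (a lower number here means that the compound disappears faster, a higher number that the compound lasts longer), where compound 1 gives 0.417 h. That places compound 1 at the lower end of the two numbers gathered so far, yet compound 2 `COc1cc2nc(N3CCc4ncccc4C3)nc(N)c2c(-c2ncccn2)c1OC` gives 0.6 h in this assay, a value within the usual scatter, so the two cannot be told apart. Compound 3 `COc1cc2nc(N3CCCN(C(=O)N4CCOCC4)CC3)cc(N)c2c(-c2ccc(F)cc2)c1OC` differs from compound 1 in one place: fluoro in place of hydrogen on an aromatic carbon. For the measured compounds named here, no measured pair shows this change. The step from compound 1 to compound 3 is expected to be small, a 1.2-fold higher number from compound 1 to compound 3 (0.08 log units; within the scatter), and not clearly beyond the scatter. Compound 3 is estimated to give 0.5 h in this assay, within a range from 0.25 h to 1 h.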

Compound 3, half-life: 0.5 h
Compound 3: middle estimate and measured number agree at the digits printed, and the stated range covers the measured number.
By their numbers in this assay, from the lowest: compounds 1, 3 and 2 (each within the scatter of the next).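

For the compounds shown here, replacing phenyl with 4-fluorophenyl gives the first measured step at this position: in this assay, the change reads a 1.2-fold higher number from compound 1 to compound 3 (0.08 log units; within the scatter) and lies within the scatter. At this carbon, para to a large group, fluoro and hydrogen therefore cannot be told apart in this measurement. No available evidence bears on this result. From the compounds shown here alone, whether an amine, a carboxylic acid or a methoxy group on this same carbon would give a step beyond the scatter stays open. Going by these compounds, whether fluoro on another carbon of this ring would do so also stays open.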